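A Methoxy Group on the Carboxyphenyl Amide

The compounds below may be only part of what the source reports. "The series", "measured", "known", "first", "only" and "open" are said of these compounds alone.

In a functional assay on MDA-MB-435 cells (Homo sapiens) for inhibition, read by MTT assay (on this read-out lower numbers stand for stronger inhibition and higher numbers for weaker inhibition), compound 1 (`CC(C)(C)C[C@@H]1N[C@@H](C(=O)Nc2ccn(CC(C)(C)O)n2)[C@H](c2cccc(Cl)c2F)[C@@]1(C#N)c1ccc(Cl)cc1F`) gives 8560 nM. Compound 2 (`CC(C)(C)C[C@@H]1N[C@@H](C(=O)Nc2ccc(C(=O)O)cc2)[C@H](c2cccc(Cl)c2F)[C@@]1(C#N)c1ccc(Cl)cc1F`), which carries a 4-carboxyphenyl group on the amide nitrogen, gives 11100 nM, and the two numbers lie within the usual scatter of each other. Compound 3 (`COc1cc(NC(=O)[C@@H]2N[C@@H](CC(C)(C)C)[C@](C#N)(c3ccc(Cl)cc3F)[C@H]2c2cccc(Cl)c2F)ccc1C(=O)O`) keeps the rest of compound 2 and turns 4-carboxyphenyl into 4-carboxy-3-methoxyphenyl. The difference is methoxy in place of hydrogen on an aromatic carbon, ortho to a carboxy group and meta to a large group.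

Among the compounds with values here, no measured pair tests a methoxy group directly. Within the data shown here, the only measured step, a 1.3-fold higher number from compound 1 to compound 2 (0.11 log units; within the scatter), exchanges the whole group on the amide nitrogen and stays within the scatter. It bears on the present question only loosely, but it gives no sign that this series responds strongly to such edits. A step beyond the scatter is therefore not expected in this assay, although a single step is thin evidence. The expected result is a 1.1-fold lower number from compound 2 to compound 3 (0.05 log units; within the scatter). Compound 3 is estimated at 10000 nM, with an expected range from 5000 nM to 20000 nM.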

Compound 3, half-maximal inhibitory concentration: 6200 nM
For compound 3 the middle estimate is 1.6-fold (0.21 log units) above the measured one; measured number inside the range.
By their numbers in this assay, from the lowest: compounds 3, 1 and 2 (each within the scatter of the next).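

In this assay, within the data shown here, the methoxy group ortho to a carboxy group gives the first direct reading at this aromatic carbon of the carboxyphenyl amide. The step is a 1.8-fold lower number from compound 2 to compound 3 (0.25 log units; within the scatter) and it does not separate the methoxy compound from its parent, so this ring carbon takes the added methoxy group without a change that can be told from repeat measurement in this read-out. The wider exchange on the amide nitrogen, a 1.4-fold lower number from compound 1 to compound 3 (0.14 log units; within the scatter), also stays within the scatter, and no information at hand explains these numbers or links them to any property of the methoxy group.

All three compounds therefore sit in one band in this assay, and the series has yet to show any edit on the amide nitrogen that yields a step beyond the scatter. Going by these compounds, what remains open is whether an ethoxy group, a hydroxy group or an amine at this same place would read differently, and whether the methoxy compound would hold its number with a methyl ester in place of the carboxylic acid.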